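Swapping a Branched Alkyl Group for a Chlorophenyl Ring

The compounds below may be only part of what the source reports. "The series", "measured", "known", "first", "only" and "open" are said of these compounds alone.

Among the compounds with values here, compound 2 `CCC(C)(CC)Cc1cnc(CCc2ccc(-c3ccccc3C(=O)O)cc2)[nH]1` gives 30 nM in an in vitro functional assay on cells for agonist activity at Bombesin receptor subtype-3 (Mus musculus), read by luminescence and calcium flux (a lower number here means that less compound is needed, a higher number that more compound is needed for the effect), the lowest of the two numbers measured so far; compound 1 `CCCCc1cnc(CCc2ccc(-c3ccccc3C(=O)O)cc2)[nH]1` gives 93 nM. Within the data shown here, the only measured step, a 3.1-fold lower number from compound 1 to compound 2 (0.49 log units; beyond the scatter), arose from exchanging one saturated group for another on the same chain carbon. Compound 3 `O=C(O)c1ccccc1-c1ccc(CCc2ncc(Cc3cccc(Cl)c3)[nH]2)cc1` departs further from this pattern: 3-chlorophenyl in place of 1-ethyl-1-methylpropyl on a saturated chain carbon bound to an aromatic carbon. Among the measured compounds shown here, no measured step places an aromatic ring at that spot, so the single step available bears on compound 3 only loosely, showing that the group on this chain carbon can be varied with a modest shift in this assay. For compound 3 a step of a 2.0-fold higher number from compound 2 to compound 3 (0.30 log units; within the scatter) is expected, leaning toward a somewhat higher number than compound 2 shows, with wide uncertainty. The estimate for compound 3 is 60 nM, with a range from 15 nM to 300 nM.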

Compound 3, half-maximal effective concentration: 31 nM
Beside the measured number, compound 3's estimate is 1.9-fold (0.29 log units) above it, and the stated range covers the measured number.
By their numbers in this assay, from the lowest: compounds 2 and 3 (each within the scatter of the next); then compound 1.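

At the saturated chain carbon bound to an aromatic carbon, this assay accepts an aromatic ring as well as a branched saturated group: a 1.0-fold higher number from compound 2 to compound 3 (0.01 log units; within the scatter), so 3-chlorophenyl and 1-ethyl-1-methylpropyl cannot be told apart here. Measured against the propyl group, the ring gives a 3.0-fold lower number from compound 1 to compound 3 (0.48 log units; beyond the scatter), which shows that a group quite unlike the branched one also stands clear of propyl. No supporting measurement is available to explain why these two different groups give matching numbers.

Whether the chlorine contributes to the number for compound 3 remains open, as the compounds shown offer no plain phenyl group for comparison. Equally open, on these data alone, is what a pyridine ring, an amine or a carboxylic acid would give on this chain carbon.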